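This account rests on a few compounds, and the source may have more. Where it says the series, first, only, none or still open, it means among the compounds named here.

Measured in a functional assay on MDA-MB-231 cells (Homo sapiens) for cytotoxicity, read by MTT assay, with a stated time of 72 h, tested at 5 uM, in the absence of a further agent; a higher number here means a weaker effect of the compound at the concentration tested, a lower number a stronger effect:

compound 1 `CC1(C)CC(N)=Nc2ccc(Cl)cc21`: 81%
compound 2 `CCNC1=Nc2ccc(Cl)cc2C(C)(C)C1`: 85.1%
compound 3 `CCCNC1=Nc2ccc(Cl)cc2C(C)(C)C1`: 82.4%

Compound 3 stands second highest of the three numbers in this assay. Its nearest neighbour is compound 1, with a number 1.4 percentage points higher from compound 1 to compound 3 (within the scatter); its furthest is compound 2, with a number 2.7 percentage points lower from compound 2 to compound 3 (within the scatter). Both separations lie within the scatter, so the three measured compounds cannot be told apart on these numbers.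

Compound 4 `CC1(C)CC(NCCCCO)=Nc2ccc(Cl)cc21` is not yet measured. It differs from compound 3 by hydroxymethyl in place of hydrogen on a saturated chain carbon, three bonds along the chain from an amine nitrogen.

Among the compounds with values here, the steps that bear on this change all concern the chain on the amine nitrogen. Building the chain from hydrogen gave a number 4.1 percentage points higher from compound 1 to compound 2 (within the scatter) and a number 1.4 percentage points higher from compound 1 to compound 3 (within the scatter); lengthening it by one carbon gave a number 2.7 percentage points lower from compound 2 to compound 3 (within the scatter). None of these moved the number beyond the scatter. Within the data shown here, no measured compound carries a hydroxyl group on this chain, so that part of the change has no precedent in the set.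

On this basis the step from compound 3 to compound 4 in this assay is expected to be a number 0.4 percentage points lower from compound 3 to compound 4 (within the scatter), not beyond the scatter in either direction. Compound 4 is therefore estimated at 82%, with a range from 70% to 93%.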

Compound 4, a percentage reported as activity, at one concentration (the size of the read-out at that concentration, not a potency): 84.9%
Estimate against measurement, compound 4: 2.9 percentage points below; low and high end bracket the measured number.
By their numbers in this assay, from the lowest: compounds 1, 3, 4 and 2 (each within the scatter of the next).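

In this assay, hydroxymethyl in place of hydrogen on a saturated chain carbon, three bonds along the chain from an amine nitrogen, brings the first hydroxyl group onto this chain, and the result is a number 2.5 percentage points higher from compound 3 to compound 4 (within the scatter). The same holds when compound 4 is read against the shorter and the unsubstituted chains, with a number 0.2 percentage points lower from compound 2 to compound 4 (within the scatter) and a number 3.9 percentage points higher from compound 1 to compound 4 (within the scatter), so neither the added length nor the hydroxyl group separates 4-hydroxybutyl from propyl, ethyl or hydrogen on the amine nitrogen, and the four compounds form one group that cannot be told apart on these numbers. No supporting data are available to explain this flat result.

Still open, from the compounds shown here alone, is whether any group on this nitrogen can move the number beyond the scatter, for instance a chain ending in a primary amine or a carboxylic acid, a longer chain, or a phenyl ring. Also open, going by these compounds, is whether the flat picture on this chain would persist with a group other than chloro on the shared core, such as fluoro or methoxy.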